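Opening the ring of compound 3 into a chain

This account rests on a few compounds, and the source may have more. Where it says the series, first, only, none or still open, it means among the compounds named here.

Three compounds share a core and differ only in the amine at the end of the chain. In a functional assay on the whole organism with Mus musculus as the target, in the maximal electroshock model, at a dose of 50 mg/kg by the oral route (on this read-out lower numbers stand for less inhibition and higher numbers for more inhibition at the one dose given (going by the name of the read-out)), compound 1 `CN(C)CCCOc1ccccc1/C=C/c1ccccc1` gives 14.2%, compound 2 `C(=C/c1ccccc1OCCCCN1CCNCC1)\c1ccccc1` gives 0%, and compound 3 `CCCN1CCN(CCCCOc2ccccc2/C=C/c2ccccc2)CC1` gives 42.9%, the highest of the three, with compound 1 nearest and compound 2 furthest.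

Compound 4 `CN(C)CCN(C)CCCCOc1ccccc1/C=C/c1ccccc1` differs from compound 3 by (2-(dimethylamino)ethyl)(methyl)amino in place of 4-propylpiperazin-1-yl on a saturated chain carbon, four bonds along the chain from an oxygen on an aromatic ring. Among the compounds with values here, two measured steps bear on this. The change from a dimethylamino to a ring amine gave a number 14.2 percentage points lower from compound 1 to compound 2 (beyond the scatter), while adding propyl to that ring nitrogen gave a number 42.9 percentage points higher from compound 2 to compound 3 (beyond the scatter). Within the data shown here, compound 4 returns to an open-chain amine that carries a dimethylamino like compound 1 yet keeps a second nitrogen in the chain, so no step of the same kind has been measured.

The expectation is therefore a moderate drop, estimated as a number 17.9 percentage points lower from compound 3 to compound 4 (beyond the scatter), because compound 1 with its open-chain amine gave 14.2%. Compound 4 is expected to give 25%, with a likely range from 5% to 50%.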

Compound 4, a percentage reported as inhibition, in the whole organism at one dose (the size of the read-out at that dose, not a potency): 0%
For compound 4 the middle estimate is 25 percentage points above the measured one; the whole stated range lies above it.
By their numbers in this assay, from the lowest: compounds 2 and 4 (each within the scatter of the next); then compound 1; then compound 3.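

In this assay, (2-(dimethylamino)ethyl)(methyl)amino in place of 4-propylpiperazin-1-yl gives a number 42.9 percentage points lower from compound 3 to compound 4 (beyond the scatter), so keeping the same number of nitrogen atoms in the end group does not preserve the read-out once the ring is gone. Set against the unsubstituted ring, the open chain gives no change at the digits printed from compound 2 to compound 4 (within the scatter), and set against the simple dimethylamino end group it gives a number 14.2 percentage points lower from compound 1 to compound 4 (beyond the scatter), so this longer open-chain amine does not match even the small amine. No measurement at hand explains these differences.

The compounds shown leave open whether the ring itself or the propyl group on its nitrogen matters more, since only the propyl-bearing ring stands out here. A piperidine ring, a morpholine ring or a butyl group on the piperazine nitrogen would help separate these two features.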